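Notes on a single fluorine exchange in the series

This account rests on a few compounds, and the source may have more. Where it says the series, first, only, none or still open, it means among the compounds named here.

Of the compounds shown here, two have been read so far in a functional assay on CWR22R cells (Homo sapiens) for antiproliferative activity, read by propidium iodide staining, with a stated time of 96 h (on this read-out lower numbers stand for stronger inhibition and higher numbers for weaker inhibition), on this series. Compound 1 (`CC(O)(CSc1ccc(S(F)(F)(F)(F)F)cc1)C(=O)Nc1ccc([N+](=O)[O-])c(C(F)(F)F)c1`) stands at 9200 nM and compound 2 (`CC(O)(CSc1ccc(S(F)(F)(F)(F)F)cc1)C(=O)Nc1cccc(S(F)(F)(F)(F)F)c1`) at 13100 nM on this measure, so the two numbers lie within the scatter of each other and neither can be ranked above the other.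

Compound 3 (`CC(O)(CSc1ccc(F)cc1)C(=O)Nc1cccc(S(F)(F)(F)(F)F)c1`) has not yet been measured. It derives from compound 2 by one exchange (one fluorine atom in place of a group of 6 heavy atoms (5 fluorine, 1 sulfur; no ring), on an aromatic carbon): one fluorine atom in place of a group of 6 heavy atoms, on an aromatic carbon, para to a large group.

Among the compounds with values here, no measured pair shows this exchange, and the data give no direct guide to its size in this assay at present. Starting from compound 2 at 13100 nM (the only anchor available), a small move is expected, not clearly beyond the scatter and, if anything, towards weaker inhibition. The expected step is a 1.1-fold higher number from compound 2 to compound 3 (0.06 log units; within the scatter) (an estimate with wide uncertainty). For compound 3 the estimated value is 15000 nM (expected range 6000 nM to 40000 nM).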

Compound 3, half-maximal inhibitory concentration: 30200 nM
Compound 3: the middle estimate sits 2.0-fold (0.30 log units) below what was measured; the range from low to high includes it.
By their numbers in this assay, from the lowest: compounds 1 and 2 (each within the scatter of the next); then compound 3.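

The exchange of the group of 6 heavy atoms (5 fluorine, 1 sulfur; no ring) for fluoro, on an aromatic carbon para to a large group, reads in this assay as a 2.3-fold higher number from compound 2 to compound 3 (0.36 log units; beyond the scatter) and so moves the number beyond the scatter. Compounds 1 and 2 both carry the larger group at this carbon and could say nothing about it, whereas this single modest step shows that the position is not indifferent to what it holds, with the smaller fluoro on the side of weaker inhibition. Nothing at hand accounts for the direction or size of this step, which remains an observation from one pair.

The compounds shown leave open how a chloro group, a methoxy group or an amine at this carbon would read relative to compound 2 and compound 3, so one pair cannot yet be taken as a trend with group size. Also open, as far as these compounds go, is whether the same exchange gives a similar step on the core of compound 1, which differs from compound 2 at the other end of the molecule.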